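The source may report more compounds than this note shows. Statements on the series, on what has been measured and on what is new or still open speak of the compounds shown alone.

Three chalcone-type pyrrolyl ketones were examined in an assay for inhibition of cytochrome P450 1A1 (Homo sapiens), read by fluorescence, using microsomes, with a stated time of 10 min; on this read-out higher numbers stand for weaker inhibition and lower numbers for stronger inhibition. Compound 3 `COc1ccccc1/C=C/C(=O)c1ccc[nH]1` gives 900 nM. Compound 1 `COc1ccc(/C=C/C(=O)c2ccc[nH]2)c(OC)c1` gives 11800 nM. Compound 2 `COc1cccc(/C=C/C(=O)c2ccc[nH]2)c1` gives 6200 nM. The difference between the cores of compound 2 and compound 3 is not broken down here. Adding a methoxy group to compound 3, (methoxy in place of hydrogen on an aromatic carbon), gave a 13-fold higher number from compound 3 to compound 1 (1.12 log units; beyond the scatter). Compound 4 `COc1cc(/C=C/C(=O)c2ccc[nH]2)cc(OC)c1` has not yet been measured. It differs from compound 2 by the same kind of change, (methoxy in place of hydrogen on an aromatic carbon), though the entering group now sits meta to the group of 9 heavy atoms rather than para to it. Because the earlier change gave a 13-fold higher number from compound 3 to compound 1 (1.12 log units; beyond the scatter), a weakening step is expected here too, a 2.3-fold higher number from compound 2 to compound 4 (0.35 log units; beyond the scatter), though its size is uncertain given the different place. Compound 4 is therefore estimated at 14000 nM, expected between 5000 nM and 40000 nM in this assay.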

Compound 4, half-maximal inhibitory concentration: 6100 nM
Compound 4: the middle estimate sits 2.3-fold (0.36 log units) above what was measured, and the stated range covers the measured number.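

In this assay, the added methoxy group gave a 1.0-fold lower number from compound 2 to compound 4 (0.01 log units; within the scatter), so the large weakening seen earlier did not recur. This change therefore does not carry over from one core to another in this series with a fixed size: the same change on two cores in this assay, a 13-fold higher number (1.12 log units; beyond the scatter) from compound 3 to compound 1 and a 1.0-fold lower number (0.01 log units; within the scatter) from compound 2 to compound 4, 13-fold (1.12 log units) apart, beyond the scatter of two such steps. The two steps do not show which matters more, the core or the place of the entering group, since both differ between them, and two steps cannot separate the two.

The compounds shown leave open whether an ethoxy group, a longer chain or an amine in the same places would follow either step. They also leave open how a carboxylic acid on the six-membered aromatic ring would read in this assay.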